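The source may report more compounds than this note shows. Statements on the series, on what has been measured and on what is new or still open speak of the compounds shown alone.

Measured so far:
- compound 1, `COc1ccc(Nc2nc(Oc3cccc(NC(=O)C=C(C)C)c3)c3sccc3n2)cc1`: 48900 nM
- compound 2, `COc1ccc(Nc2nc(Oc3cccc(NC(=O)C=C(C)C)c3)c3sccc3n2)cn1`: 36900 nM
- compound 3, `C=CC(=O)Nc1cccc(Oc2nc(Nc3cccc(C#N)c3)nc3ccsc23)c1`: > 50000 nM

In an ADME assay on L02 cells (Homo sapiens) for inhibition, read by MTT assay, with a stated time of 72 h (a lower number here means a stronger inhibitor, a higher number a weaker inhibitor), compound 3 stands only at a limit, > 50000 nM, which is the edge of what the test reports rather than a number. For the measured compounds named here, compound 1 and compound 2 each give a number, and the one measured step, a 1.3-fold lower number from compound 1 to compound 2 (0.12 log units; within the scatter), shows that swapping the ring on the nitrogen hardly moves the readout.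

Compound 4, `CC(C)=CC(=O)Nc1cccc(Oc2nc(Nc3cccc(C#N)c3)nc3ccsc23)c1`, differs from compound 3 in one place: 2-methylprop-1-en-1-yl in place of vinyl on a carbonyl carbon. Going by the values given here, no measured pair here changes the group on the carbonyl carbon, so no measured step bears on it directly. Compound 1 and compound 2, which already carry the 2-methylprop-1-en-1-yl group, both sit close to the limit (the limit of > 50000 nM in this assay, at which 1 of the 3 values shown sits), and nothing suggests a step beyond the scatter.

For compound 4 the expected step is therefore a number no higher from compound 3 to compound 4 (the limit leaves the size open), that is, no change beyond the scatter in this assay. Compound 4 is estimated at 50000 nM, with a range from 20000 nM to 120000 nM, and it may well again come back only as a limit.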

Compound 4, half-maximal inhibitory concentration: > 50000 nM
Compound 4: a limit, no number (the forecaster's own chance of this, stated with the estimate: 55%); the middle value lies on the limit itself.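

Like compound 3, compound 4 comes back in this assay only as a limit, > 50000 nM, so the step between these two compounds cannot be read, and the change from vinyl to 2-methylprop-1-en-1-yl on the carbonyl carbon has no measured size. Going by these compounds, the other new comparisons concern the group on the nitrogen: 3-cyanophenyl in place of 6-methoxypyridin-3-yl gives an at least 1.3-fold higher number from compound 2 to compound 4 (0.13 log units; that floor lies within the scatter), and 3-cyanophenyl in place of 4-methoxyphenyl gives an at least 1.0-fold higher number from compound 1 to compound 4 (0.00 log units; that floor lies within the scatter), so each step has only a floor and its true size stays unknown. The top edge of the test now bounds part of the results: the limit of > 50000 nM in this assay, at which 2 of the 4 values shown sit.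

On these data alone, it remains open how an amine or a longer chain on the carbonyl carbon would read in this assay. Also open, as far as these compounds go, is whether any group on the nitrogen would give vinyl compounds a readable number.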